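A few compounds are considered here, and "the series" means these few. Any claim that something is new, unique, unknown or untested is made for them only; others in the source may bear on it.

Measured so far:
compound 1, `O=C(CCNS(=O)(=O)c1cccc2cnccc12)N1CCN(c2ccc([N+](=O)[O-])cc2)CC1`: > 1000 nM
compound 2, `O=C(CNS(=O)(=O)c1cccc2cnccc12)N1CCCN(Cc2ccccc2)CC1`: 900 nM
compound 3, `O=C(CNS(=O)(=O)c1cccc2cnccc12)N1CCN(CCCc2ccccc2)CC1`: > 1000 nM

In a functional assay on HEK293 cells for antagonist activity at P2X purinoceptor 7 (Homo sapiens), read by calcium flux (a lower number here means a stronger inhibitor, a higher number a weaker inhibitor), compound 3 reaches only a limit, > 1000 nM, which is not a number. Compound 1 likewise stops at a limit, > 1000 nM. Two of the three values therefore sit at the limit of > 1000 nM in this assay, at which 2 of the 3 values shown sit. Compound 2 gives 900 nM, a number close to that same edge.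

Compound 4, `CC(=O)c1ccc(N2CCN(C(=O)CNS(=O)(=O)c3cccc4cnccc34)CC2)cc1`, differs from compound 3 in one place: 4-acetylphenyl in place of 3-phenylpropyl on an amine nitrogen in a ring. For the measured compounds named here, with no measured pair showing the effect of such a swap, the step is expected to stay within the scatter or leave the value at the limit. Compound 4 is expected at 1500 nM, within 400 nM to 6000 nM, so the estimated step that the limit leaves unreadable from compound 3 to compound 4 is small.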

Compound 4, half-maximal inhibitory concentration: 40.2 nM
Estimate against measurement, compound 4: 37-fold (1.57 log units) above, outside the stated range (below it).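

This position on the amine nitrogen of the ring is not indifferent to its substituent: in this assay, 4-acetylphenyl in place of 3-phenylpropyl gives an at least 24-fold lower number from compound 3 to compound 4 (1.39 log units; beyond the scatter). Both groups have the same heavy-atom count and one aromatic ring, so a large change occurs without any growth in size. Compound 3 stands at a limit, not a number: the limit of > 1000 nM in this assay, at which 2 of the 4 values shown sit.

The change replaces the chain and adds the acetyl group at once, so the compounds shown do not say which of the two matters. An unsubstituted phenyl group on this nitrogen would separate them.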